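Swapping Chloro for Bromo in a Toll-like Receptor 8 Inhibitor

The source may report more compounds than this note shows. Statements on the series, on what has been measured and on what is new or still open speak of the compounds shown alone.

Within the data shown here, compound 1 `N#Cc1c(Cl)cccc1Oc1ccc(-c2nnco2)cc1` is one of two compounds measured in an assay on HEK293 cells for inhibition of Toll-like receptor 8 (Homo sapiens), with a stated time of 16 h; on this read-out higher numbers stand for weaker inhibition and lower numbers for stronger inhibition. In this assay compound 1 gives 1400 nM, the lower of the two numbers, so on this read-out it is the stronger inhibitor of the pair. Among the measured compounds shown here, its only measured neighbour is compound 2 `Nc1c(Cl)cccc1Oc1ccc(-c2nnco2)cc1`, which in this assay gives 5290 nM. For the measured compounds named here, the step of a 3.8-fold higher number from compound 1 to compound 2 (0.58 log units; beyond the scatter) is the sole measured step, and it concerns a different group from the one at issue here.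

Compound 3 `N#Cc1c(Br)cccc1Oc1ccc(-c2nnco2)cc1` differs from compound 1 by bromo in place of chloro on an aromatic carbon. Going by the values given here, no measured step speaks to this exchange: the single measured step changed another group, so the data give no direct sign of how replacing one halogen with another moves this read-out. In the absence of such a sign, compound 3 is expected to stay close to compound 1, with a step of a 1.2-fold lower number from compound 1 to compound 3 (0.07 log units; within the scatter) that is expected to remain within the usual scatter. The estimate for compound 3 in this assay is 1200 nM, with a range from 500 nM to 3000 nM.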

Compound 3, half-maximal inhibitory concentration: 880 nM
Estimate against measurement, compound 3: 1.4-fold (0.13 log units) above; measured number inside the range.
By their numbers in this assay, from the lowest: compounds 3 and 1 (each within the scatter of the next); then compound 2.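

In this assay, putting bromo in place of chloro on this aromatic carbon, ortho to a cyano group, gives a 1.6-fold lower number from compound 1 to compound 3 (0.20 log units; within the scatter), so the two numbers cannot be told apart. Among these compounds, this is the first measured look at the halogen position itself, as the earlier step, a 3.8-fold higher number from compound 1 to compound 2 (0.58 log units; beyond the scatter), lay beyond the scatter but concerned amino in place of cyano on the same ring. Here, by contrast, one halogen can stand in for the other without a change that the assay can resolve, and nothing measured here bears on why the two halogens give such similar numbers.

The compounds shown leave open whether a group of a different kind at this position, such as a methyl, a methoxy or an amine, would keep the number in the same region or move it beyond the scatter. They also leave open whether bromo in place of chloro would give a similarly small step in compound 2, which carries amino where compound 1 carries cyano.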